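The compounds below may be only part of what the source reports. "The series", "measured", "known", "first", "only" and "open" are said of these compounds alone.

Compound 1 `COc1ccc(C(=O)/C(=C/c2ccc(Cl)cc2Cl)CCOC(C)=O)cc1` gives 69200 nM.
Compound 3 `COc1ccc(C(=O)/C(=C/c2ccc(Cl)cc2Cl)CC(C)OC(C)=O)cc1` gives 40300 nM.
Compound 2 `COc1ccc(C(=O)/C(=C/C2CCCCC2)CCOC(C)=O)cc1` reports only a limit, > 100000 nM.

In a functional assay on A549 cells (Homo sapiens) for inhibition, read by XTT assay, with a stated time of 48 h (on this read-out higher numbers stand for weaker inhibition and lower numbers for stronger inhibition), the three compounds share one core. The step of a 1.7-fold lower number from compound 1 to compound 3 (0.23 log units; within the scatter) goes with methyl in place of hydrogen on a saturated chain carbon bound to an oxygen next to a carbonyl group and a saturated chain carbon. The step of an at least 1.4-fold higher number from compound 1 to compound 2 (0.15 log units; that floor lies within the scatter) goes with cyclohexyl in place of 2,4-dichlorophenyl on a double-bonded chain carbon bound to a double-bonded chain carbon, and the value of compound 2 is a limit of the assay (the limit of > 100000 nM in this assay, at which 1 of the 3 values shown sits). Compound 4 `COc1ccc(C(=O)/C(=C/C2CCCCC2)CC(C)OC(C)=O)cc1` differs from compound 3 by cyclohexyl in place of 2,4-dichlorophenyl on a double-bonded chain carbon bound to a double-bonded chain carbon, the same change as from compound 1 to compound 2 at the same place. Compound 4 is expected to show the step of a 2.4-fold higher number from compound 3 to compound 4 (0.37 log units; beyond the scatter), set beside an at least 1.4-fold higher number from compound 1 to compound 2 (0.15 log units; that floor lies within the scatter). That expectation rests on compound 2 reporting only the limit > 100000 nM. The estimate for compound 4 is 95000 nM, between 45000 nM and 250000 nM, with a fair chance that only a limit is reported.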

Compound 4, half-maximal inhibitory concentration: 98000 nM
The estimate for compound 4 lay 1.0-fold (0.01 log units) below the measured number; the range from low to high includes it.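

In this assay, cyclohexyl in place of 2,4-dichlorophenyl gives a 2.4-fold higher number from compound 3 to compound 4 (0.39 log units; beyond the scatter). This shows a measurable loss on the core of compound 3, but it does not establish that the change has the same size on the core of compound 1: the same change on two cores in this assay, an at least 1.4-fold higher number (0.15 log units; that floor lies within the scatter) from compound 1 to compound 2 and a 2.4-fold higher number (0.39 log units; beyond the scatter) from compound 3 to compound 4; the limit leaves it open whether they differ. The methyl change on the cyclohexyl pair gives an at least 1.0-fold lower number from compound 2 to compound 4 (0.00 log units; that floor lies within the scatter) as its step. Compound 2 reports only a limit: the same change on two cores in this assay, a 1.7-fold lower number (0.23 log units; within the scatter) from compound 1 to compound 3 and an at least 1.0-fold lower number (0.00 log units; that floor lies within the scatter) from compound 2 to compound 4; the limit leaves it open whether they differ.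

The compounds shown leave open how an unsubstituted phenyl or a pyridine would behave on a double-bonded chain carbon bound to a double-bonded chain carbon. They also leave open what a free alcohol or an amine would do in place of the ester.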